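The source may report more compounds than this note shows. Statements on the series, on what has been measured and on what is new or still open speak of the compounds shown alone.

In a functional assay with Rattus norvegicus as the target (on this read-out lower numbers stand for stronger inhibition and higher numbers for weaker inhibition), compound 1 (`COc1ccc2oc(=O)c(=O)[nH]c2c1`) gives 15000 nM, compound 2 (`COc1ccc2[nH]c(=O)c(=O)oc2c1`) gives 28000 nM, and compound 3 (`O=c1[nH]c2cc(C(F)(F)F)ccc2oc1=O`) gives 100000 nM, the highest of the three numbers and so the weakest inhibition. Compound 4 (`O=c1[nH]c2cc([N+](=O)[O-])ccc2oc1=O`) alters one group of compound 3: nitro in place of trifluoromethyl on an aromatic carbon. For the measured compounds named here, one measured step bears on this change: a 6.7-fold higher number from compound 1 to compound 3 (0.82 log units; beyond the scatter), a modest step where trifluoromethyl replaced methoxy. Going by the values given here, no measured compound carries nitro, so this step offers only a rough size and no firm direction. In this assay, the expected result is a modest move towards a lower number, estimated as a 2.2-fold lower number from compound 3 to compound 4 (0.35 log units; beyond the scatter). Compound 4 is estimated at 45000 nM, within a range of 12000 nM to 150000 nM.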

Compound 4, half-maximal inhibitory concentration: 800 nM
Estimate against measurement, compound 4: 56-fold (1.75 log units) above, outside the stated range (below it).
By their numbers in this assay, from the lowest: compound 4; then compounds 1 and 2 (each within the scatter of the next); then compound 3.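

For the compounds shown here, on this aromatic carbon, the choice of group matters far more than the earlier compounds showed: nitro in place of trifluoromethyl gives a 130-fold lower number from compound 3 to compound 4 (2.10 log units; beyond the scatter) in this assay, while nitro in place of methoxy gives a 19-fold lower number from compound 1 to compound 4 (1.27 log units; beyond the scatter) in the same read-out. Going by these compounds alone, both steps are large, whereas the only earlier step, a 6.7-fold higher number from compound 1 to compound 3 (0.82 log units; beyond the scatter) and no more, was modest. No measurement here explains this gain with nitro. From the compounds shown here alone, whether an amine, a nitrile or a carboxylic acid on this carbon would match nitro remains open. So does whether nitro would give a similar gain on the core of compound 2.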